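Swapping bromo for trifluoromethyl on the benzyl amide

A few compounds are considered here, and "the series" means these few. Any claim that something is new, unique, unknown or untested is made for them only; others in the source may bear on it.

Measured so far:
- Compound 1, `CCc1ccccc1N(CC(=O)NCc1ccc(OC)c(OC)c1)S(=O)(=O)c1ccc(C)cc1`: 282 nM
- Compound 2, `CCc1ccccc1N(CC(=O)NCc1cccc(OC(F)(F)F)c1)S(=O)(=O)c1ccc(C)cc1`: 427 nM
- Compound 3, `CCc1ccccc1N(CC(=O)NCc1ccc(Br)cc1)S(=O)(=O)c1ccc(C)cc1`: 22.9 nM

All three share a core and differ only in the aryl group attached to the saturated carbon next to the amide nitrogen. In a functional assay on CHO-K1 cells for antagonist activity at prostaglandin E2 receptor EP1 subtype (Homo sapiens), read by FLIPR and calcium flux (a lower number here means a stronger inhibitor, a higher number a weaker inhibitor), compound 3 gives 22.9 nM, the lowest of the three numbers and therefore the strongest inhibitor here: a 12-fold lower number from compound 1 to compound 3 (1.09 log units; beyond the scatter) and a 19-fold lower number from compound 2 to compound 3 (1.27 log units; beyond the scatter), both beyond the scatter. Compound 1 and compound 2 sit close together, since a 1.5-fold higher number from compound 1 to compound 2 (0.18 log units; within the scatter).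

Compound 4, `CCc1ccccc1N(CC(=O)NCc1ccc(C(F)(F)F)cc1)S(=O)(=O)c1ccc(C)cc1`, has not yet been measured. It keeps the core of compound 3 and makes one change: trifluoromethyl in place of bromo on an aromatic carbon. For the measured compounds named here, no measured step isolates this exact swap; the steps from compound 1 and compound 2 to compound 3 replace the whole aryl group, so they show that a single group on that ring can shift the number a great deal, but not how bromo and trifluoromethyl compare. With only that to go on, compound 4 is expected to land near compound 3, and the step of a 1.3-fold higher number from compound 3 to compound 4 (0.12 log units; within the scatter) is estimated to stay within the scatter, with wide uncertainty. Compound 4 is estimated at 30 nM in this assay, ranging from 9 nM to 100 nM.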

Compound 4, inhibition constant: 209 nM
Compound 4: the middle estimate sits 7.0-fold (0.84 log units) below what was measured; the whole stated range lies below it.
By their numbers in this assay, from the lowest: compound 3; then compounds 4, 1 and 2 (each within the scatter of the next, the first and the last beyond it).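

In this assay, changing only the group on one aromatic carbon gives a 9.1-fold higher number from compound 3 to compound 4 (0.96 log units; beyond the scatter), so the low number of compound 3 depends on bromo in particular and not merely on that ring carrying a single group there. The 4-(trifluoromethyl)phenyl group does not hold on to that advantage: a 1.3-fold lower number from compound 1 to compound 4 (0.13 log units; within the scatter) leaves compound 4 level with the 3,4-dimethoxyphenyl compound, and a 2.0-fold lower number from compound 2 to compound 4 (0.31 log units; beyond the scatter) is only a small separation from the 3-(trifluoromethoxy)phenyl compound. Nothing available here accounts for the gap between bromo and trifluoromethyl.

The compounds shown leave open whether a chloro, an iodo, a methyl or a nitrile on that same aromatic carbon would stay close to compound 3 or fall back towards compound 4. They also leave open whether swapping bromo for trifluoromethyl would give a step of similar size with a longer chain or an amine elsewhere on the shared core.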